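Swapping a Flexible Chain for a Pyridine Ring

The source may report more compounds than this note shows. Statements on the series, on what has been measured and on what is new or still open speak of the compounds shown alone.

compound 1 `COc1cccc(OC)c1C(=O)Nc1c[nH]nc1C(=O)NCCN1CCCC1`: > 50000 nM
compound 2 `COc1cccc(OC)c1C(=O)Nc1c[nH]nc1C(=O)NCCCOC(C)C`: > 50000 nM

Compound 1 `COc1cccc(OC)c1C(=O)Nc1c[nH]nc1C(=O)NCCN1CCCC1` was tested in an ADME assay on MRC5 cells (Homo sapiens) for inhibition, with a stated time of 72 h (a higher number here means that more compound is needed for the effect, a lower number that less compound is needed), and its result is a limit of the assay, > 50000 nM. Compound 2 `COc1cccc(OC)c1C(=O)Nc1c[nH]nc1C(=O)NCCCOC(C)C` was tested in the same way and also returns a limit, > 50000 nM. The step that the two limits leave unreadable from compound 1 to compound 2 therefore has no readable size. Compound 2 thus stands at the limit of the assay, where (the limit of > 50000 nM in this assay, at which 2 of the 2 values shown sit).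

Compound 3 `COc1cccc(OC)c1C(=O)Nc1c[nH]nc1C(=O)Nc1ccccn1` differs from compound 2 by pyridin-2-yl in place of 3-isopropoxypropyl on an amide-type nitrogen. Among the compounds with values here, no measured step involves a pyridin-2-yl group, and the single measured step gives no size at all, so there is no evidence on which to expect a change in either direction. With both known values sitting at the limit, compound 3 is expected to behave alike, and the step of a number no higher from compound 2 to compound 3 (the limit leaves the size open) is estimated to be nothing beyond the scatter. Compound 3 is estimated at 50000 nM, with a range from 10000 nM to 200000 nM, and a further limit is the likelier outcome.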

Compound 3, half-maximal effective concentration: > 50000 nM
Compound 3 ended at the assay's limit; the forecaster's own chance of this, stated with the estimate: 75%; the middle value lies on the limit itself.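

Compound 1, compound 2 and compound 3 all end at a limit in this assay, so no step among them can be read: the limit of > 50000 nM in this assay, at which 3 of the 3 values shown sit.

The compounds shown leave open how much of each is needed for the effect, and whether pyridin-2-yl or either chain changes that amount at all.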